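The compounds below may be only part of what the source reports. "The series", "measured", "known", "first", "only" and "open" are said of these compounds alone.

Measured in a functional assay on BGC-823 cells (Homo sapiens) for inhibition, read by MTT assay, with a stated time of 72 h; a lower number here means a stronger inhibitor, a higher number a weaker inhibitor:
- compound 1 `Cc1cc(N2CC[C@@H](C)[C@@H](N(C)c3ncnc4[nH]ccc34)C2)n2nc(SCC3CC3)nc2n1`: 36500 nM
- compound 2 `Cc1cc(N2CC[C@@H](C)[C@@H](N(C)c3ncnc4[nH]ccc34)C2)n2nc(SCCc3ccccc3)nc2n1`: 28000 nM

Compound 1 carries the higher of the two numbers, but its nearest neighbour is compound 2 and the step of a 1.3-fold lower number from compound 1 to compound 2 (0.12 log units; within the scatter) lies within the scatter, so the two compounds cannot be told apart on these data.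

Compound 3 `C=CCSc1nc2nc(C)cc(N3CC[C@@H](C)[C@@H](N(C)c4ncnc5[nH]ccc45)C3)n2n1` has not yet been measured in this assay. It differs from compound 1 as follows: vinyl in place of cyclopropyl on a saturated chain carbon bound to a sulfur. Within the data shown here, the only measured step that bears on this position is a 1.3-fold lower number from compound 1 to compound 2 (0.12 log units; within the scatter), in which the cyclopropyl on the saturated chain carbon bound to a sulfur was replaced by benzyl without a shift beyond the scatter. Among the measured compounds shown here, the move to vinyl on the same carbon has no direct precedent here, and nothing in the two measured values points to a direction for it. For compound 3 the expected step is a 1.0-fold lower number from compound 1 to compound 3 (0.02 log units; within the scatter), meaning no change beyond the scatter. Compound 3 is estimated at 35000 nM, with a likely range from 15000 nM to 80000 nM.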

Compound 3, half-maximal inhibitory concentration: 40900 nM
Beside the measured number, compound 3's estimate is 1.2-fold (0.07 log units) below it; low and high end bracket the measured number.
By their numbers in this assay, from the lowest: compounds 2, 1 and 3 (each within the scatter of the next).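

In this assay, vinyl in place of cyclopropyl on a saturated chain carbon bound to a sulfur gives a 1.1-fold higher number from compound 1 to compound 3 (0.05 log units; within the scatter), and vinyl in place of benzyl on the same carbon gives a 1.5-fold higher number from compound 2 to compound 3 (0.16 log units; within the scatter). The position now holds three different groups that cannot be told apart on these data: among compounds 1, 2 and 3, neither the loss of the three-membered ring of compound 1 nor the presence of a double bond outside aromatic rings in compound 3 produces a step beyond the scatter, so the flat reading from the first pair now extends to a group with no ring. No supporting evidence is available to explain this flat reading.

As far as these compounds go, all three groups at this position contain only carbon and hydrogen, so it remains open whether an amine, a carboxylic acid or a longer chain on the same carbon would produce a step beyond the scatter. Also open, from the compounds shown here alone, is whether an oxygen in place of the sulfur would move the number in this assay, or whether any change at this position can separate compounds at all.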